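Thiosemicarbazones: chlorophenyl to pyrrolyl on the imine carbon

The source may report more compounds than this note shows. Statements on the series, on what has been measured and on what is new or still open speak of the compounds shown alone.

For the measured compounds named here, compound 1 `COc1ccc(/C=N/NC(=S)NC(C)(C)[C@H]2CC=C(C)CC2)cc1` carries a methoxy group on its aromatic ring and is the only member of the set with a number: in a functional assay on UACC-62 cells (Homo sapiens) for inhibition, read by sulforhodamine B assay, with a stated time of 48 h (on this read-out lower numbers stand for stronger inhibition of growth and higher numbers for weaker inhibition of growth), compound 1 gives 70400 nM. Compound 2 `CC1=CC[C@H](C(C)(C)NC(=S)N/N=C/c2ccc(O)cc2)CC1` has hydrogen in place of methyl on that oxygen. In this assay compound 2 reaches only the limit of > 100000 nM. Compound 3 `CC1=CC[C@H](C(C)(C)NC(=S)N/N=C/c2ccc(Cl)cc2)CC1` bears chloro in place of methoxy. In this assay compound 3 likewise reaches only the limit of > 100000 nM. Compound 3 thus stands at the limit of > 100000 nM in this assay, at which 2 of the 3 values shown sit, with no number of its own. On these data alone, the steps read an at least 1.4-fold higher number from compound 1 to compound 2 (0.15 log units; that floor lies within the scatter) and an at least 1.4-fold higher number from compound 1 to compound 3 (0.15 log units; that floor lies within the scatter), while a step that the two limits leave unreadable from compound 2 to compound 3 stays open.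

Compound 4 `CC1=CC[C@H](C(C)(C)NC(=S)N/N=C/c2ccc[nH]2)CC1` differs from compound 3 by 1H-pyrrol-2-yl in place of 4-chlorophenyl on a carbon with a double bond to nitrogen. Going by the values given here, none of the measured steps exchanges the aromatic ring itself; all three swap substituents on a six-membered ring, and two of them end at a limit. They give no ground to expect a move beyond the scatter in this assay, so the step that the limit leaves unreadable from compound 3 to compound 4 is expected to be small. Compound 4 is accordingly estimated at 120000 nM, between 40000 nM and 400000 nM, and a limit rather than a number is the more likely outcome.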

Compound 4, concentration for total growth inhibition: 49900 nM
The estimate for compound 4 lay 2.4-fold (0.38 log units) above the measured number, and the stated range covers the measured number.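

In this assay the exchange of the aromatic ring itself, on a carbon with a double bond to nitrogen, leaves a measurable value: compound 4, with 1H-pyrrol-2-yl, is the second compound in the set with a number rather than a limit. Against the 4-chlorophenyl and 4-hydroxyphenyl compounds, the steps read an at least 2.0-fold lower number from compound 3 to compound 4 (0.30 log units; that floor lies within the scatter) and an at least 2.0-fold lower number from compound 2 to compound 4 (0.30 log units; that floor lies within the scatter), so neither floor shows a move beyond the scatter, although the true size of each step could be larger. Against the 4-methoxyphenyl compound, the exchange reads a 1.4-fold lower number from compound 1 to compound 4 (0.15 log units; within the scatter) and so does not separate the two numbers, while the other two values remain limits: the limit of > 100000 nM in this assay, at which 2 of the 4 values shown sit.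

The compounds shown leave open how 1H-pyrrol-2-yl compares with a furan-2-yl ring on the same carbon, or with 1-methyl-1H-pyrrol-2-yl, which carries a methyl group in place of the ring's nitrogen hydrogen. They also leave open whether any exchange at this place moves the value beyond the scatter, and the step between the two limits cannot be read.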